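A Carboxamide in Place of the Methylsulfinyl Group

The source may report more compounds than this note shows. Statements on the series, on what has been measured and on what is new or still open speak of the compounds shown alone.

Compound 1 `C[S+]([O-])c1ccc(CNC(=O)c2ccc(C(C)(C)C)cc2)cc1` was tested in an assay on HeLa cells with Bile acid receptor (Homo sapiens) as the target, read by a luciferase reporter, with a stated time of 24 h (a higher number here means that more compound is needed for the effect, a lower number that less compound is needed), where compound 1 gives 1300 nM. Going by the values given here, of the two numbers known, this is the highest. Its nearest neighbour, compound 2 `Cc1cc(CNC(=O)c2ccc(C(C)(C)C)cc2)ccc1C(=O)O`, gives 160 nM in this assay, and the gap between these two values lies beyond the usual scatter. Among the compounds with values here, no single-point step between compounds 1 and 2 is defined, so the two values simply stand side by side.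

The next compound, compound 3 `CC(C)(C)c1ccc(C(=O)NCc2ccc(C(N)=O)cc2)cc1`, differs from compound 1 at one spot: a group of 3 heavy atoms (1 carbon, 1 nitrogen, 1 oxygen; no ring) in place of a group of 3 heavy atoms (1 carbon, 1 oxygen, 1 sulfur; no ring), on an aromatic carbon. The group that leaves is replaced by a carbamoyl group on the same aromatic carbon of the six-membered aromatic ring of carbon only.

Within the data shown here, with no step between measured compounds to lean on, the account expects a small move toward a lower number in this assay, of a size near the edge of the scatter, starting from compound 1. Compound 3 is therefore estimated at 600 nM in this assay, with a range from 150 nM to 2500 nM. This estimate means a step of a 2.2-fold lower number from compound 1 to compound 3 (0.34 log units; beyond the scatter).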

Compound 3, half-maximal effective concentration: 3800 nM
Estimate against measurement, compound 3: 6.3-fold (0.80 log units) below, and the stated range ends below it.
By their numbers in this assay, from the lowest: compound 2; then compound 1; then compound 3.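

Going by these compounds alone, at the aromatic carbon para to a large group, the carbamoyl group does not match the sulfur-bearing group it replaces: in this assay the exchange gives a 2.9-fold higher number from compound 1 to compound 3 (0.47 log units; beyond the scatter) and so offers the first reading of a single change at this position, with more compound needed after it. The two groups have the same count of heavy atoms, while the carbamoyl group adds a hydrogen-bond donor and a double bond outside aromatic rings, so a change that leaves the heavy-atom count untouched is still enough to move the number beyond the usual scatter. No measurement at hand bears on the reason for this step.

Going by these compounds, whether an amine, a nitrile or a methyl sulfone on the same aromatic carbon would give a number nearer that of compound 1 or that of compound 3 remains open. Also open, on these data alone, is whether a carbamoyl group with a methyl on its nitrogen would follow compound 3, and whether this single step would keep its direction and size on other versions of the shared core.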